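A few compounds are considered here, and "the series" means these few. Any claim that something is new, unique, unknown or untested is made for them only; others in the source may bear on it.

Of the compounds shown here, two share the core of compound 1 and have been measured in an assay on brain cells (strain Sprague-Dawley) for displacement of a labelled ligand from adenosine receptor A1 (Rattus norvegicus), read by scintillation counting, with a stated time of 60 min; on this read-out higher numbers stand for weaker inhibition and lower numbers for stronger inhibition. Compound 1 `COc1ccc(OCc2nc3c(c(=O)n(C)c(=O)n3C)n2C)cc1` gives 4670 nM, and compound 2 `CCn1c(=O)c2c(ncn2C)n(CC)c1=O` gives 5610 nM. Compound 1 thus has the lower of the two numbers, but the gap to compound 2 lies within the scatter, so the two cannot be set apart.

Compound 3 `Cn1c(=O)c2c(nc(COc3ccc(Br)cc3)n2C)n(C)c1=O` is not yet measured. It differs from compound 1 in one place: bromo in place of methoxy on an aromatic carbon, a bromo in place of a methoxy on an aromatic carbon. Among the measured compounds shown here, no measured pair shows what this change does, so the expectation rests on compound 1 alone.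

The expected step is a 1.3-fold lower number from compound 1 to compound 3 (0.13 log units; within the scatter), and it is estimated to stay within the scatter rather than move clearly either way. Compound 3 is therefore expected to give 3500 nM, with a range from 1200 nM to 10000 nM.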

Compound 3, inhibition constant: 3690 nM
Estimate against measurement, compound 3: 1.1-fold (0.02 log units) below; the range from low to high includes it.
By their numbers in this assay, from the lowest: compounds 3, 1 and 2 (each within the scatter of the next).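

In this assay, among the compounds shown here, bromo in place of methoxy gives a 1.3-fold lower number from compound 1 to compound 3 (0.10 log units; within the scatter), the first measured pair at this position on the aromatic ring, para to a large group. The change from 4-methoxyphenyl to 4-bromophenyl removes a hydrogen-bond acceptor and a heavy atom from the substituent, yet the step stays within the usual scatter, so this pair does not separate the two groups. No independent measurement is available to explain this result.

Going by these compounds, whether an amine, a carboxylic acid or a longer chain at this position would also leave the number within the scatter remains open. For the compounds shown here, with only this one pair, it is also unknown whether bromo in place of methoxy would give a similar step on another core.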